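Swapping Bromo for Fluoro on the Benzyl Arm

This account rests on a few compounds, and the source may have more. Where it says the series, first, only, none or still open, it means among the compounds named here.

Compound 1 `O=C(/C=C/c1ccc(OCc2cn(Cc3cccc(F)c3)nn2)cc1)c1ccc(Br)cc1`: 34%
Compound 2 `COc1ccc(C(=O)/C=C/c2ccc(OCc3cn(Cc4cccc(F)c4)nn3)cc2)cc1`: 48%
Compound 3 `O=C(/C=C/c1ccc(OCc2cn(Cc3cccc(Br)c3)nn2)cc1)c1ccc([N+](=O)[O-])cc1`: 21%

These values come from a functional assay on MIA PaCa-2 cells (Homo sapiens) for inhibition, read by MTT assay, with a stated time of 48 h, tested at 10 uM; on this read-out lower numbers stand for less inhibition of growth and higher numbers for more inhibition of growth at the one concentration tested. Compound 3 stands lowest of the three, beyond the scatter below both compound 1 and compound 2. Compound 4 `O=C(/C=C/c1ccc(OCc2cn(Cc3cccc(F)c3)nn2)cc1)c1ccc([N+](=O)[O-])cc1` differs from compound 3 by fluoro in place of bromo on an aromatic carbon. Among the measured compounds shown here, the only measured step, a number 14 percentage points higher from compound 1 to compound 2 (beyond the scatter), concerns a different ring and does not bear on this change. For the measured compounds named here, compounds 1 and 2 both carry the fluoro form, but neither pairs directly with compound 3, so no step for this swap is known. A step near or within the scatter is therefore expected, a number 4 percentage points higher from compound 3 to compound 4 (within the scatter). Compound 4 is estimated at 25%, within 12% to 40%.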

Compound 4, percent growth inhibition at one concentration: 32%
Compound 4: the middle estimate sits 7 percentage points below what was measured; the range from low to high includes it.
By their numbers in this assay, from the lowest: compound 3; then compounds 4 and 1 (each within the scatter of the next); then compound 2.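

In this assay, the benzyl arm proves able to shift the result: fluoro in place of bromo gives a number 11 percentage points higher from compound 3 to compound 4 (beyond the scatter) with the nitro ring unchanged. With 3-fluorobenzyl held constant, nitro in place of methoxy gives a number 16 percentage points lower from compound 2 to compound 4 (beyond the scatter) and nitro in place of bromo gives a number 2 percentage points lower from compound 1 to compound 4 (within the scatter) on the other ring. No measurement shown here accounts for these differences.

Going by these compounds, whether the bromo-to-fluoro step holds when methoxy or bromo sits on the other ring remains open. So does the effect of a chloro, methyl or amine on the benzyl arm.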